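Thiazole carbohydrazides: removal of the acylurea, para analogue

The source may report more compounds than this note shows. Statements on the series, on what has been measured and on what is new or still open speak of the compounds shown alone.

Measured so far:
- compound 1 `CNc1nc(C(F)(F)F)c(C(=O)N/N=C/c2cccc(C(F)(F)F)c2)s1`: > 100 ug/mL
- compound 2 `CN(C(=O)NC(=O)c1ccccc1F)c1nc(C(F)(F)F)c(C(=O)N/N=C/c2cccc(C(F)(F)F)c2)s1`: 20.5 ug/mL
- compound 3 `CN(C(=O)NC(=O)c1ccccc1F)c1nc(C(F)(F)F)c(C(=O)N/N=C/c2ccc(C(F)(F)F)cc2)s1`: 4.98 ug/mL

The series is read in a functional assay on MCF7 cells (Homo sapiens) for inhibition, read by MTT assay, with a stated time of 72 h; a higher number here means a weaker inhibitor, a lower number a stronger inhibitor. Compound 1 gives only a limit of the assay, > 100 ug/mL, and no number. Compound 2 gives 20.5 ug/mL and compound 3 gives 4.98 ug/mL; compound 3 has the lowest number of the two that were resolved.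

Two single changes connect the measured compounds. From compound 2 to compound 3 the change is 4-(trifluoromethyl)phenyl in place of 3-(trifluoromethyl)phenyl on a carbon with a double bond to nitrogen, and the step is a 4.1-fold lower number from compound 2 to compound 3 (0.61 log units; beyond the scatter). From compound 2 to compound 1 the change is hydrogen in place of ((2-fluorophenyl)carbonyl)carbamoyl on a nitrogen on an aromatic ring, and the step is an at least 4.8-fold higher number from compound 2 to compound 1 (0.68 log units; beyond the scatter); its size is open at the upper end because of the limit of > 100 ug/mL in this assay, at which 1 of the 3 values shown sits.

Compound 4 `CNc1nc(C(F)(F)F)c(C(=O)N/N=C/c2ccc(C(F)(F)F)cc2)s1` is not yet measured. From compound 3 to compound 4 the change is hydrogen in place of ((2-fluorophenyl)carbonyl)carbamoyl on a nitrogen on an aromatic ring; the place around it reads the same as in the step from compound 2 to compound 1, so this is the same change made on the other core. Going by these compounds, for compound 4 in this assay the expected step is a 12-fold higher number from compound 3 to compound 4 (1.08 log units; beyond the scatter), resting on the step from compound 2 to compound 1, an at least 4.8-fold higher number from compound 2 to compound 1 (0.68 log units; beyond the scatter), whose true size is unknown beyond its limit. The estimate for compound 4 in this assay is 60 ug/mL, expected to lie between 20 ug/mL and 150 ug/mL, with a real chance that only a limit is reported.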

Compound 4, half-maximal inhibitory concentration: > 100 ug/mL
Compound 4 ended at the assay's limit; the forecaster's own chance of this, stated with the estimate: 45%; middle value at least 1.6-fold (0.22 log units) away from the limit.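

In this assay, hydrogen in place of ((2-fluorophenyl)carbonyl)carbamoyl on the nitrogen gives an at least 20-fold higher number from compound 3 to compound 4 (1.30 log units; beyond the scatter), so the change goes the same way on both cores shown and carries the same direction from one to the other. Direction is what transfers here; a comparison of size does not follow, and the larger printed figure on this core is no evidence of a larger effect: the same change on two cores in this assay, an at least 4.8-fold higher number (0.68 log units; beyond the scatter) from compound 2 to compound 1 and an at least 20-fold higher number (1.30 log units; beyond the scatter) from compound 3 to compound 4; the limit leaves it open whether they differ How far either step runs past the assay's limit also stays unknown, which means that any dependence of this change on the core can be neither claimed nor excluded: the limit of > 100 ug/mL in this assay, at which 2 of the 4 values shown sit.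

Within the data shown here, compound 1 and compound 4 both end at that limit, so the swap of 3-(trifluoromethyl)phenyl for 4-(trifluoromethyl)phenyl cannot be read on the core with hydrogen on the nitrogen, and the step between compound 2 and compound 3 remains the only reading of that swap. The compounds shown also leave open which part of ((2-fluorophenyl)carbonyl)carbamoyl the difference depends on, since nothing between that whole group and hydrogen appears here, such as an acetyl group or a carbamoyl group carrying a phenyl ring without fluorine.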